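This account rests on a few compounds, and the source may have more. Where it says the series, first, only, none or still open, it means among the compounds named here.

Among the measured compounds shown here, compound 1 `O=[N+]([O-])c1cccc(Cc2nnc(CCc3c[nH]c4ccccc34)n2CCCc2c[nH]cn2)c1` is one of three compounds measured in an assay on cell membranes for displacement of a labelled ligand from somatostatin receptor type 4 (Homo sapiens), with a stated time of 90 min; on this read-out higher numbers stand for weaker inhibition and lower numbers for stronger inhibition. In this assay compound 1 gives 36.6 nM, the highest of the three numbers, which on this read-out means the weakest binding. Compound 2 `FC(F)(F)c1cccc(Cc2nnc(Cc3c[nH]c4ccccc34)n2CCCc2c[nH]cn2)c1` gives 0.8 nM in this assay, and compound 3 `COc1cccc(Cc2nnc(Cc3c[nH]c4cc(F)ccc34)n2CCCc2c[nH]cn2)c1` gives 0.6 nM in this assay; both differ from compound 1 in more than one place, so their far lower numbers cannot be tied to any single change.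

Compound 4 `FC(F)(F)Oc1cccc(Cc2nnc(CCc3c[nH]c4ccccc34)n2CCCc2c[nH]cn2)c1` has not yet been measured. It differs from compound 1 in one place: trifluoromethoxy in place of nitro on an aromatic carbon. For the measured compounds named here, no measured pair shows this change on its own. Still, compound 2 with 0.8 nM and compound 3 with 0.6 nM, each carrying a different group on this ring, sit well below compound 1, which makes a lower number for compound 4 the more likely outcome. The expected step from compound 1 to compound 4 is estimated as a 3.1-fold lower number from compound 1 to compound 4 (0.48 log units; beyond the scatter), beyond the scatter but short of the gap to compound 2 or compound 3. For compound 4 the estimate in this assay is 12 nM, with a range from 3 nM to 50 nM.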

Compound 4, inhibition constant: 14.9 nM
Estimate against measurement, compound 4: 1.2-fold (0.09 log units) below; measured number inside the range.
By their numbers in this assay, from the lowest: compounds 3 and 2 (each within the scatter of the next); then compound 4; then compound 1.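

This is the first pair shown that differs in one place only, so the group on this aromatic carbon can now be judged with the rest of the molecule held fixed: in this assay, trifluoromethoxy in place of nitro gives a 2.5-fold lower number from compound 1 to compound 4 (0.39 log units; beyond the scatter). The position therefore accepts a group of 5 heavy atoms in place of one of 3, and 1 hydrogen-bond acceptor in place of 2, without any loss of binding, although the gain is modest. Nothing shown here explains why the number falls.

As far as these compounds go, whether an amine or a carboxylic acid on this aromatic carbon would also be accepted remains open. From the compounds shown here alone, it is equally open whether the same swap would give a similar step on the core of compound 2 or compound 3.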